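A Trifluoromethoxy Variant in a Weakly Active Pair

The compounds below may be only part of what the source reports. "The series", "measured", "known", "first", "only" and "open" are said of these compounds alone.

Compound 2 `CCOc1ccc2nc(C(=O)Nc3c(F)cc(-c4cccc(F)c4)cc3F)c(C)c(O)c2c1` and compound 1 `Cc1c(C(=O)Nc2c(F)cc(-c3cccc(F)c3)cc2F)nc2ccc(F)cc2c1O` share one core and differ only in the group on an aromatic carbon: ethoxy in compound 2, fluoro in compound 1. In a functional assay on Hep 3B2 cells (Homo sapiens) for antiproliferative activity, read by MTT assay, with a stated time of 24 h, tested at 0.41 ug/mL (on this read-out higher numbers stand for a stronger effect at the one concentration tested and lower numbers for a weaker effect), compound 1 gives 4.85%, and in this assay compound 2 gives 0.26%. The step of a number 4.6 percentage points lower from compound 1 to compound 2 (within the scatter) shows that the two numbers sit within the scatter of each other, so neither compound stands apart from the other; both readings are small. Compound 3 `Cc1c(C(=O)Nc2c(F)cc(-c3cccc(F)c3)cc2F)nc2ccc(OC(F)(F)F)cc2c1O` carries the change (trifluoromethyl in place of ethyl on an oxygen on an aromatic ring), which, cut one bond further out, reads ethoxy to trifluoromethoxy. For the measured compounds named here, the only measured step that bears on this site is the exchange of fluoro for ethoxy, and it moved the read-out by an amount within the scatter. Nothing measured here shows that exchanging the ethyl on that oxygen for trifluoromethyl shifts this assay in either direction, so the expected step of a number 2.2 percentage points higher from compound 2 to compound 3 (within the scatter) is none beyond the scatter. Compound 3 is therefore estimated at 2.5% in this assay, with a range from -6% to 12%.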

Compound 3, a percentage reported as inhibition, at one concentration (the size of the read-out at that concentration, not a potency): 5.62%
Beside the measured number, compound 3's estimate is 3.1 percentage points below it; the measured number falls inside the stated range.
By their numbers in this assay, from the lowest: compounds 2, 1 and 3 (each within the scatter of the next).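

In this assay, putting trifluoromethyl in place of the ethyl on the oxygen gives a number 5.4 percentage points higher from compound 2 to compound 3 (within the scatter) and so does not separate the two compounds. For the compounds shown here, measured against the smaller fluoro group, the same site with trifluoromethoxy gives a number 0.8 percentage points higher from compound 1 to compound 3 (within the scatter), so this aromatic carbon has now carried three different groups, fluoro, ethoxy and trifluoromethoxy, and no step among them rises beyond the scatter of repeated measurements. Nothing available explains these readings or ties them to any property of the groups.

The compounds shown leave open whether anything placed on this aromatic carbon can move the read-out clearly, for example an amine, a carboxylic acid or a longer chain on the oxygen such as butoxy. With only one concentration and three small readings, they also leave open whether fluoro, ethoxy and trifluoromethoxy truly behave alike at this site or only look alike under these conditions, where a real difference between them could stay hidden in the scatter.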